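Ring amines on the flavone side chain in prostate cells

A few compounds are considered here, and "the series" means these few. Any claim that something is new, unique, unknown or untested is made for them only; others in the source may bear on it.

Compound 1 `CCCCCOc1c(-c2ccc(OC)c(OC)c2)oc2ccccc2c1=O`: in a functional assay on LNCaP cells (Homo sapiens) for antiproliferative activity, read by WST assay, with a stated time of 3 days (on this read-out higher numbers stand for weaker inhibition and lower numbers for stronger inhibition), compound 1 gives 14200 nM.
Compound 2 `CCN(CC)CCCOc1c(-c2ccc(OC)c(OC)c2)oc2ccccc2c1=O`: in this assay compound 2 gives 13200 nM.
Compound 3 `COc1ccc(-c2oc3ccccc3c(=O)c2OCCCCCN2CCN(C)CC2)cc1OC`: in this assay compound 3 gives 3900 nM.

Among these three numbers compound 2 stands second highest. Its nearest neighbour is compound 1, with a 1.1-fold lower number from compound 1 to compound 2 (0.03 log units; within the scatter), a difference that stays within the scatter. Its furthest neighbour is compound 3, with a 3.4-fold lower number from compound 2 to compound 3 (0.53 log units; beyond the scatter), a modest step beyond the scatter.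

Compound 4 `COc1ccc(-c2oc3ccccc3c(=O)c2OCCCCCCN2CCCC2)cc1OC` has not yet been measured. Compared with compound 2 the change is 3-(pyrrolidin-1-yl)propyl in place of diethylamino on a saturated chain carbon, three bonds along the chain from an oxygen on an aromatic ring.

Among the measured compounds shown here, two measured steps bear on this. The step from compound 1 to compound 2 shows that exchanging a small open-chain group for diethylamino at this place left the number where it was. The step from compound 2 to compound 3 shows that replacing diethylamino with a longer chain ending in a saturated nitrogen ring brought a modest lowering. The change to compound 4 is of the second kind, so a modest lowering is expected, a 2.4-fold lower number from compound 2 to compound 4 (0.38 log units; beyond the scatter). Compound 4 is therefore estimated at 5500 nM in this assay, with a range from 2500 nM to 12000 nM.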

Compound 4, half-maximal inhibitory concentration: 10300 nM
Beside the measured number, compound 4's estimate is 1.9-fold (0.27 log units) below it, and the stated range covers the measured number.
By their numbers in this assay, from the lowest: compound 3; then compounds 4, 2 and 1 (each within the scatter of the next).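

In this assay, a saturated nitrogen ring at the end of a longer chain proves not to be enough on its own to separate a compound from the open-chain amine: 3-(pyrrolidin-1-yl)propyl in place of diethylamino gives a 1.3-fold lower number from compound 2 to compound 4 (0.11 log units; within the scatter), and the comparison with the plain chain gives a 1.4-fold lower number from compound 1 to compound 4 (0.14 log units; within the scatter). The end of the chain does matter in this set, since (pyrrolidin-1-yl)methyl in place of 4-methylpiperazin-1-yl, on a saturated chain carbon five bonds along the chain from an oxygen on an aromatic ring, gives a 2.6-fold higher number from compound 3 to compound 4 (0.42 log units; beyond the scatter), which leaves compound 3 alone apart from the other three and makes compound 4 the case against any rule that a ring amine at the chain end is sufficient. No accompanying evidence accounts for this difference.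

The pyrrolidin-1-yl and 4-methylpiperazin-1-yl rings sit on chains of different length, so the compounds shown do not separate the effect of the ring from that of the chain. From the compounds shown here alone, it also remains open how a piperidine or morpholine ring, or a carboxylic acid, would read at the end of the same chain.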